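Swapping an aromatic ring for a pyrrolidine in compound 4

The compounds below may be only part of what the source reports. "The series", "measured", "known", "first", "only" and "open" are said of these compounds alone.

Compound 1, `O=C(c1ccccc1)N1CCC(NS(=O)(=O)c2cc(S(=O)(=O)c3ccccc3)ccc2C(F)(F)F)CC1`, in an assay on isolated protein for displacement of a labelled ligand from secreted frizzled-related protein 1 (Homo sapiens), read by fluorescence polarization, with a stated time of 30 min (a lower number here means a stronger inhibitor, a higher number a weaker inhibitor), gives 70 nM.
Compound 2, `O=C(c1cccc(Cl)c1)N1CCC(NS(=O)(=O)c2cc(S(=O)(=O)c3ccccc3)ccc2C(F)(F)F)CC1`, in this assay gives 300 nM.
Compound 3, `CN(C)c1ccc(C(=O)N2CCC(NS(=O)(=O)c3cc(S(=O)(=O)c4ccccc4)ccc3C(F)(F)F)CC2)cn1`, in this assay gives 40 nM.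

Compound 1 stands second highest of these three numbers in this assay. Its nearest neighbour is compound 3, a 1.8-fold lower number from compound 1 to compound 3 (0.24 log units; within the scatter), a difference that falls within the usual scatter of repeated measurements. The furthest is compound 2, a 4.3-fold higher number from compound 1 to compound 2 (0.63 log units; beyond the scatter), a modest step beyond that scatter.

Compound 4, `O=C([C@H]1CCNC1)N1CCC(NS(=O)(=O)c2cc(S(=O)(=O)c3ccccc3)ccc2C(F)(F)F)CC1`, has not yet been measured. Its change from compound 1 is pyrrolidin-3-yl in place of phenyl on a carbonyl carbon. Both measured steps alter the group on the same carbonyl carbon, but each keeps a six-membered aromatic ring there; neither exchanges it for a five-membered non-aromatic ring carrying a hydrogen-bond donor. They do show that this carbonyl carbon accepts changes within a modest span, in either direction. Lacking a close precedent, the expectation leans toward a weaker inhibitor, with a modest 2.9-fold higher number from compound 1 to compound 4 (0.46 log units; beyond the scatter) expected in this assay. Compound 4 is therefore estimated at about 200 nM, with a range from 50 nM to 1000 nM.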

Compound 4, half-maximal inhibitory concentration: 40 nM
Estimate against measurement, compound 4: 5.0-fold (0.70 log units) above, and the stated range ends above it.
By their numbers in this assay, from the lowest: compounds 3, 4 and 1 (each within the scatter of the next); then compound 2.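

In this assay, this carbonyl carbon does not need an aromatic ring: a five-membered non-aromatic ring carrying a hydrogen-bond donor gives a 1.8-fold lower number from compound 1 to compound 4 (0.24 log units; within the scatter) and no change at the digits printed from compound 3 to compound 4 (within the scatter), so the exchange leaves the number level with those of both compounds. The step from the chlorinated compound, a 7.5-fold lower number from compound 2 to compound 4 (0.88 log units; beyond the scatter), shows that pyrrolidin-3-yl also avoids the loss seen with 3-chlorophenyl, so two quite different groups on this carbon, pyrrolidin-3-yl and 6-(dimethylamino)pyridin-3-yl, match benzoyl's parent phenyl within the scatter. Nothing available here explains why this exchange is tolerated.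

Still open, on these data alone, is whether the ring nitrogen of pyrrolidin-3-yl matters at all, which a cyclopentyl group on the same carbonyl carbon would test. Also open, as far as these compounds go, are the mirror-image form of pyrrolidin-3-yl and a methyl group on its nitrogen.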